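A few compounds are considered here, and "the series" means these few. Any claim that something is new, unique, unknown or untested is made for them only; others in the source may bear on it.

Going by the values given here, compound 3 `COc1ccc(C2CC(c3cc(Cl)c(C)cc3O)=NN2c2ccc(S(N)(=O)=O)cc2)cc1OC` gives 4150 nM in a functional assay on EKVX cells (Homo sapiens) for antiproliferative activity, with a stated time of 48 h (a lower number here means a stronger inhibitor of growth, a higher number a weaker inhibitor of growth), the highest of the three numbers measured so far. Compound 1 `Cc1cc(O)c(C2=NN(c3ccc(S(N)(=O)=O)cc3)C(c3ccccc3O)C2)cc1Cl` gives 1990 nM in this assay, and compound 2 `Cc1cc(O)c(C2=NN(c3ccc(S(N)(=O)=O)cc3)C(c3ccccc3Cl)C2)cc1Cl` gives 1950 nM. The two steps into compound 3 are alike: a 2.1-fold higher number from compound 1 to compound 3 (0.32 log units; beyond the scatter) and a 2.1-fold higher number from compound 2 to compound 3 (0.33 log units; beyond the scatter), both modest losses on changing the aryl on the saturated ring carbon; the exchange between compound 1 and compound 2 itself, a 1.0-fold lower number from compound 1 to compound 2 (0.01 log units; within the scatter), stays within the scatter.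

Compound 4 `COc1ccc(C2CC(c3cc(Cl)c(C)cc3O)=NN2c2ccc(S(N)(=O)=O)cc2)c(OC)c1OC` differs from compound 3 by methoxy in place of hydrogen on an aromatic carbon. Among the compounds with values here, no measured step adds a methoxy to this aryl; the only steps that touch this part of the molecule are the two into compound 3, and they show that enlarging the substitution on this aryl brought a modest loss rather than a gain. A further methoxy is therefore expected to leave the number about where compound 3 stands or move it slightly higher, a step not clearly beyond the scatter, a 1.2-fold higher number from compound 3 to compound 4 (0.08 log units; within the scatter). Compound 4 is estimated at 5000 nM in this assay, within a range from 2000 nM to 12000 nM.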

Compound 4, concentration for 50% growth inhibition: 3260 nM
For compound 4 the middle estimate is 1.5-fold (0.19 log units) above the measured one; low and high end bracket the measured number.
By their numbers in this assay, from the lowest: compounds 2, 1, 4 and 3 (each within the scatter of the next, the first and the last beyond it).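

In this assay, methoxy on the aromatic carbon ortho to a large group and ortho to a methoxy group, turning 3,4-dimethoxyphenyl into 2,3,4-trimethoxyphenyl, is tolerated without a change beyond the scatter (a 1.3-fold lower number from compound 3 to compound 4 (0.10 log units; within the scatter)). The 2,3,4-trimethoxyphenyl compound also stays within the scatter of both compounds with a smaller aryl on the saturated ring carbon (a 1.7-fold higher number from compound 2 to compound 4 (0.22 log units; within the scatter); a 1.6-fold higher number from compound 1 to compound 4 (0.21 log units; within the scatter)), so further methoxy substitution on this aryl does not extend the modest losses seen on the steps into compound 3. No measurement at hand bears on why these steps are so small.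

Going by these compounds, whether an amine or a carboxylic acid at this aromatic carbon would move the number beyond the scatter remains open. So does the contribution of the chloro, methyl and hydroxy substituents on the other aryl, which all four compounds share.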